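Estimating Cell Toxicity for an Unmeasured Analogue

The source may hold more compounds than are shown below. What is called first, only, known or untested is meant among the compounds shown, and "the series" means these compounds.

Compound 1 `CN(C)CCn1cnnc1-c1cc(Oc2ccc(NC(=O)Nc3ccc(F)c(F)c3)cc2F)ccn1`: > 50000 nM
Compound 2 `CCN(CC)CCn1cnnc1-c1cc(Oc2ccc(NC(=O)Nc3ccccc3C(F)(F)F)cc2F)ccn1`: 23500 nM

Within the data shown here, in an ADME assay on WI-38 cells (Homo sapiens) for cytotoxicity, read by MTT assay, with a stated time of 72 h (on this read-out lower numbers stand for stronger inhibition and higher numbers for weaker inhibition), compound 2 gives 23500 nM, the only plain number among the two measured compounds. For compound 1 the read-out is the limit of > 50000 nM in this assay, at which 1 of the 2 values shown sits, a limit rather than a number. Compound 3 `CCN(CC)CCn1cnnc1-c1cc(Oc2ccc(NC(=O)Nc3ccc(F)c(F)c3)cc2F)ccn1` differs from compound 2 by 3,4-difluorophenyl in place of 2-(trifluoromethyl)phenyl on an amide-type nitrogen. Among the measured compounds shown here, no measured pair shows this change on its own, so the expectation rests on the two values alone. Compound 3 is expected to move by a 1.7-fold higher number from compound 2 to compound 3 (0.23 log units; within the scatter) toward weaker inhibition, and a limit is a real possibility. The estimate for compound 3 is 40000 nM, with a range from 15000 nM to 100000 nM.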

Compound 3, half-maximal inhibitory concentration: > 50000 nM
Compound 3 ended at the assay's limit; the forecaster's own chance of this, stated with the estimate: 40%; at least 1.2-fold (0.09 log units) between middle value and limit.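

Replacing 2-(trifluoromethyl)phenyl with 3,4-difluorophenyl on the amide-type nitrogen, with the rest of the molecule unchanged, gives in this assay an at least 2.1-fold higher number from compound 2 to compound 3 (0.32 log units; beyond the scatter), so this position does influence the read-out. On these data alone, compound 3 gives a limit rather than a number, so the full size of this step stays unknown. The step between dimethylamino and diethylamino cannot be read, because both compounds carrying these groups sit at a limit: the limit of > 50000 nM in this assay, at which 2 of the 3 values shown sit.

Still open, as far as these compounds go, is what a plain phenyl or a 4-chlorophenyl would give on this nitrogen. Also open, from the compounds shown here alone, is whether a longer chain on the amine would bring the read-out back to a plain number.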